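Replacing the Cyanophenyl Arm of Compound 1

This account rests on a few compounds, and the source may have more. Where it says the series, first, only, none or still open, it means among the compounds named here.

Compound 1 `CC/C(=C(/c1ccc(/C=C/C(=O)O)cc1)c1cc2ccccc2[nH]1)c1ccccc1C#N` gives the lowest number of the two compounds measured in a functional assay on MCF7 cells (Homo sapiens) for inhibition (on this read-out lower numbers stand for stronger inhibition and higher numbers for weaker inhibition), at 9 nM. Compound 2 `CC/C(=C(/c1ccc(/C=C/C(=O)O)cc1)c1cc2ccccc2[nH]1)c1ccccc1OC(F)(F)F` gives 206 nM in this assay; the step between them is a 23-fold higher number from compound 1 to compound 2 (1.36 log units; beyond the scatter). Compound 3 `CC/C(=C(/c1ccc(/C=C/C(=O)O)cc1)c1cc2ccccc2[nH]1)c1ccc(C(F)(F)F)cc1Cl` has not yet been measured in this assay. It differs from compound 1 in one place: 2-chloro-4-(trifluoromethyl)phenyl in place of 2-cyanophenyl on a double-bonded chain carbon bound to a double-bonded chain carbon and a saturated chain carbon. Within the data shown here, the only measured step that bears on this change is the one from compound 1 to compound 2, which was large and ran toward weaker inhibition when the cyano group was exchanged for another group. Compound 3 likewise loses the cyano group and the acceptor it carries, so a step of comparable size toward a higher number is expected. For compound 3 the estimated value in this assay is 150 nM, within 40 nM to 600 nM, an expected step of a 17-fold higher number from compound 1 to compound 3 (1.22 log units; beyond the scatter).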

Compound 3, half-maximal inhibitory concentration: 27 nM
For compound 3 the middle estimate is 5.6-fold (0.74 log units) above the measured one; the whole stated range lies above it.
By their numbers in this assay, from the lowest: compound 1; then compound 3; then compound 2.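

The result shows that losing the nitrile at this position need not cost much in this assay: there is a 3.0-fold higher number from compound 1 to compound 3 (0.48 log units; beyond the scatter), a modest step that still lies beyond the scatter. The size of the change therefore depends on the group that enters, not only on the nitrile that leaves, since there is a 7.6-fold lower number from compound 2 to compound 3 (0.88 log units; beyond the scatter). The 2-chloro-4-(trifluoromethyl)phenyl arm carries no hydrogen-bond acceptor, yet compound 3 stays nearer to compound 1 than to compound 2, and no available evidence accounts for this difference between the arms.

The compounds shown leave open whether the chlorine or the trifluoromethyl group matters more, a question that a 2-chlorophenyl or a 4-(trifluoromethyl)phenyl arm would address. On these data alone, it also remains open how a nitrile would behave alongside a chlorine on this ring, or how an amine would behave in its place.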